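A few compounds are considered here, and "the series" means these few. Any claim that something is new, unique, unknown or untested is made for them only; others in the source may bear on it.

In a functional assay on MCF7 cells (Homo sapiens) for inhibition, read by sulforhodamine B assay, with a stated time of 48 h (on this read-out lower numbers stand for stronger inhibition of growth and higher numbers for weaker inhibition of growth), three compounds have been measured so far. Compound 1, `N#CCC1=NN=C(c2ccc(Br)cc2)C(CC(=O)c2ccc(Br)cc2)O1`, gives 30400 nM. Compound 2, `N#CCC1=C(C#N)CC(c2ccc(Br)cc2)=C(CC(=O)c2ccc(Br)cc2)O1`, gives 12000 nM, and compound 3, `N#CCC1=NN=C(c2ccc([N+](=O)[O-])cc2)C(CC(=O)c2ccc(Br)cc2)O1`, gives 36000 nM. Among these three numbers compound 1 holds the second highest; its nearest neighbour is compound 3, whose value sits within the scatter of that of compound 1, while compound 2 lies beyond the scatter with the lowest number of the three.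

The compound now in question is compound 4, `N#CCC1=NN=C(c2ccc(Br)cc2)C(CC(=O)c2ccc([N+](=O)[O-])cc2)O1`. It differs from compound 1 in one place: nitro in place of bromo on an aromatic carbon. The same exchange, nitro in place of bromo on an aromatic carbon, has been measured once already, in the step of a 1.2-fold higher number from compound 1 to compound 3 (0.07 log units; within the scatter). That step stayed within the scatter, so, by analogy, no shift beyond the scatter is expected in this assay when going from compound 1 to compound 4; no direction can be read from a single step that itself falls inside the scatter. Compound 4 is therefore estimated at 34000 nM, with a range from 15000 nM to 80000 nM. The expected step is a 1.1-fold higher number from compound 1 to compound 4 (0.05 log units; within the scatter).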

Compound 4, concentration for 50% growth inhibition: 32000 nM
For compound 4 the middle estimate is 1.1-fold (0.03 log units) above the measured one; measured number inside the range.
By their numbers in this assay, from the lowest: compound 2; then compounds 1, 4 and 3 (each within the scatter of the next).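

Compound 1 carries two 4-bromophenyl groups, and until now only one of them had been exchanged; here the other one is, and in this assay the result is a 1.1-fold higher number from compound 1 to compound 4 (0.02 log units; within the scatter). Read together with a 1.2-fold higher number from compound 1 to compound 3 (0.07 log units; within the scatter), this shows that among these compounds, 4-bromophenyl to 4-nitrophenyl leaves the number indistinguishable from that of compound 1 on either group, even though three heavy atoms enter where one leaves and the nitro brings two hydrogen-bond acceptors that the bromo does not have. Nothing available here gives a reason for this, so it stands as a plain observation.

On these data alone, both exchanges keep the core of compound 1 and swap only bromo for nitro, so it remains open whether a quite different group at this place, such as an amine, a carboxylic acid or a longer chain, would move the number beyond the scatter. As far as these compounds go, it is also open whether nitro on both aromatic rings at once would give a number that can be told apart from that of compound 1, and whether nitro would behave the same way on the core of compound 2.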